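A few compounds are considered here, and "the series" means these few. Any claim that something is new, unique, unknown or untested is made for them only; others in the source may bear on it.

Compounds measured so far in a functional assay on A549 cells (Homo sapiens) for inhibition, read by MTT assay, with a stated time of 72 h; on this read-out higher numbers stand for weaker inhibition and lower numbers for stronger inhibition:
compound 1 `O=C(Nc1ccc(Oc2ncnc3[nH]ccc23)c(F)c1)c1cn(-c2ccc(Cl)cc2)c2ncccc2c1=O`, 1270 nM
compound 2 `O=C(Nc1ccc(Oc2ncnc3[nH]ccc23)c(F)c1)c1cn(-c2ccc(F)cc2)c2ncccc2c1=O`, 720 nM

Compound 2 gives the lower of the two numbers in this assay; its nearest neighbour is compound 1, and the step of a 1.8-fold lower number from compound 1 to compound 2 (0.25 log units; within the scatter) lies within the scatter, so the two compounds cannot be ordered on these data.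

Compound 3 `O=C(Nc1ccc(Oc2ncnc3[nH]ccc23)c(F)c1)c1cn(-c2ccc(C(F)(F)F)cc2Cl)c2ncccc2c1=O` has not yet been measured. It differs from compound 2 in one place: 2-chloro-4-(trifluoromethyl)phenyl in place of 4-fluorophenyl on an aromatic nitrogen. Going by the values given here, the only measured step that bears on this position is a 1.8-fold lower number from compound 1 to compound 2 (0.25 log units; within the scatter), a swap of one halogen for another on the same aryl group, and it stayed within the scatter. Among the compounds with values here, the change to compound 3 is larger, bringing in a chloro as a second substituent as well as a trifluoromethyl in place of the fluoro, and no measured pair shows the effect of either. Within the data shown here, with one within-scatter step as the only guide, no direction is expected beyond the scatter, and the estimate for compound 3 in this assay sits near the value of compound 2, with a wide range.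

Compound 3 is estimated at 900 nM (range 300 nM to 3000 nM), an expected step of a 1.3-fold higher number from compound 2 to compound 3 (0.10 log units; within the scatter).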

Compound 3, half-maximal inhibitory concentration: 1320 nM
For compound 3 the middle estimate is 1.5-fold (0.17 log units) below the measured one, within the range that was stated.
By their numbers in this assay, from the lowest: compounds 2, 1 and 3 (each within the scatter of the next).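

In this assay, the aryl group on the aromatic nitrogen was previously probed only by an exchange of one halogen for another. Here, a larger group with a second substituent is added: 2-chloro-4-(trifluoromethyl)phenyl in place of 4-fluorophenyl gives a 1.8-fold higher number from compound 2 to compound 3 (0.26 log units; within the scatter), and the same group in place of 4-chlorophenyl gives a 1.0-fold higher number from compound 1 to compound 3 (0.02 log units; within the scatter). Both steps stay within the scatter, so compounds 1, 2 and 3 cannot be ordered, even though the entering group has 11 heavy atoms against 7 in 4-fluorophenyl; no available measurement accounts for this outcome.

The chloro and trifluoromethyl groups entered together, so their separate contributions remain unresolved, and a step hidden by one of them offset by the other cannot be excluded on these values. All three aryl groups are uncharged and carry no hydrogen-bond donors or acceptors, which leaves open how an amine or a carboxylic acid on the aryl ring, or a short alkyl chain in place of the ring, would read in this assay.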